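Compound 1 and Its Mirror Image in the Series

The compounds below may be only part of what the source reports. "The series", "measured", "known", "first", "only" and "open" are said of these compounds alone.

Compound 1 `C[C@@H](Sc1nc2c(cnn2C)c(=O)n1-c1ccccc1)c1ccccc1` is a thioether-linked phenylethyl derivative of the shared core. In an assay on isolated protein for inhibition of Retinaldehyde dehydrogenase 3 (Homo sapiens) (a higher number here means a weaker inhibitor, a lower number a stronger inhibitor), compound 1 gives 34 nM, the lowest number among the three measured compounds. Compound 2 `C#Cc1ccc(-n2c(SC(C)c3ccccc3)nc3c(cnn3C)c2=O)cc1` carries an ethynyl group on the aromatic ring attached to the core and gives 520 nM in this assay, while compound 3 `CC(Sc1nc2c(cnn2C)c(=O)n1-c1ccc(C#N)cc1)c1ccccc1`, with a cyano group in that place, gives 200 nM. Within the data shown here, the only step between measured compounds is a 2.6-fold lower number from compound 2 to compound 3 (0.41 log units; beyond the scatter).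

Compound 4 `C[C@H](Sc1nc2c(cnn2C)c(=O)n1-c1ccccc1)c1ccccc1` differs from compound 1 in one respect: the two compounds have the same atoms and bonds and differ only in configuration as drawn: 1 of 1 stereo elements differ; a stereocentre at a saturated chain carbon is drawn R in compound 1 and S in compound 4. Among the measured compounds shown here, none of the measured steps bears on a change of configuration; the cyano-for-ethynyl step concerns a substituent on the aromatic ring and says nothing about the stereocentre. The estimate for compound 4 therefore rests on the value of compound 1 alone and carries a wide range. Compound 4 is expected to show a 3.5-fold higher number from compound 1 to compound 4 (0.55 log units; beyond the scatter), a somewhat higher number in this assay, giving an estimated 120 nM with a range from 25 nM to 1200 nM.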

Compound 4, half-maximal inhibitory concentration: 1640 nM
Beside the measured number, compound 4's estimate is 14-fold (1.14 log units) below it; measured number outside the range, above it.
By their numbers in this assay, from the lowest: compound 1; then compound 3; then compound 2; then compound 4.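

In this assay, inverting the stereocentre at the saturated chain carbon gives a 48-fold higher number from compound 1 to compound 4 (1.68 log units; beyond the scatter), a large step, whereas the earlier change on the aromatic ring, a 2.6-fold lower number from compound 2 to compound 3 (0.41 log units; beyond the scatter), was modest. The earlier compounds shown here said nothing about this carbon; this pair shows that, with the rest of the structure unchanged, the R form as drawn gives the much lower number. The whole gap can be assigned to the stereocentre because of what the two structures share: the fact that compounds 1 and 4 differ only in the configuration as drawn.

As far as these compounds go, compounds 2 and 3 are drawn with no configuration at this carbon, so it remains open how far their numbers would separate into two forms. Also open, from the compounds shown here alone, is whether the same preference holds with an ethyl group in place of the methyl on this carbon, or with an amine on the aromatic ring attached to the core.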